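Swapping Cyclopropyl for Methyl: Expected Shift in Tolerated Concentration

The source may report more compounds than this note shows. Statements on the series, on what has been measured and on what is new or still open speak of the compounds shown alone.

Measured so far:
compound 1 `CC(C)n1ncc2c(C(=O)NC3CCN(C)C3)cc(C3CC3)nc21`: 33800 nM
compound 2 `Cc1cc(C(=O)NC2CCN(C)C2)c2cnn(C(C)C)c2n1`: > 300000 nM
compound 3 `Cc1nn(C(C)(C)C)c2nc(C3CC3)cc(C(=O)NCCN(C)C)c12`: 56300 nM

These three compounds were tested in an ADME assay on Vero cells (Chlorocebus sabaeus) for cytotoxicity, read by neutral red uptake, with a stated time of 3 days; a higher number here means that more compound is tolerated, a lower number that less compound is tolerated. For compound 2 the value > 300000 nM is a limit of the assay rather than a number. Compound 1 and compound 2 share a core and differ in one place: methyl in place of cyclopropyl on an aromatic carbon. That change gave an at least 8.8-fold higher number from compound 1 to compound 2 (0.94 log units; beyond the scatter). Compound 3 stands apart from compound 1, and the difference between the two cores is not broken down here. Compound 3 and compound 1 give numbers within the usual scatter of each other, so no order between them is claimed.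

Compound 4 `Cc1cc(C(=O)NCCN(C)C)c2c(C)nn(C(C)(C)C)c2n1` has not yet been measured. It differs from compound 3 by methyl in place of cyclopropyl on an aromatic carbon. This is the same kind of change as that from compound 1 to compound 2, though the surroundings are not identical: in compound 1 the place is meta to a group of 9 heavy atoms, whereas in compound 3 it is meta to a (2-(dimethylamino)ethyl)carbamoyl group (8 heavy atoms). Because the measured step was an at least 8.8-fold higher number from compound 1 to compound 2 (0.94 log units; beyond the scatter), compound 4 is expected to show a step of similar size, a 5.3-fold higher number from compound 3 to compound 4 (0.73 log units; beyond the scatter). Compound 3 already gives 56300 nM. Such a step would carry compound 4 toward (the limit of > 300000 nM in this assay, at which 1 of the 3 values shown sits), so a limit rather than a number is quite possible. The estimate for compound 4 in this assay is 300000 nM, with a range from 100000 nM to 1000000 nM.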

Compound 4, half-maximal cytotoxic concentration: 184000 nM
Estimate against measurement, compound 4: 1.6-fold (0.21 log units) above; measured number inside the range.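

In this assay, putting methyl in place of cyclopropyl on the aromatic carbon gave a 3.3-fold higher number from compound 3 to compound 4 (0.51 log units; beyond the scatter), so the direction of the change seen on the core of compound 1 also holds on the core of compound 3. Within the data shown here, the size of the step, however, did not carry over unchanged, and this is the main lesson for anyone tempted to transfer a measured step directly from one core to another: the same change on two cores in this assay, an at least 8.8-fold higher number (0.94 log units; beyond the scatter) from compound 1 to compound 2 and a 3.3-fold higher number (0.51 log units; beyond the scatter) from compound 3 to compound 4, at least 2.7-fold (0.43 log units) apart, beyond the scatter of two such steps The comparison rests on only two pairs of compounds, so it shows neither that the same direction would appear on a third core nor which of the differences between the two cores sets the size of the step.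

The compounds shown leave open what other groups on this aromatic carbon would do, for example ethyl, a longer carbon chain, or an amine, and whether their numbers would fall near those of the methyl or the cyclopropyl compounds. They also leave open whether the step would keep its size on the core of compound 3 if a longer chain replaced the (2-(dimethylamino)ethyl)carbamoyl group.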